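Swapping phenyl for furan on the amide of a thiazole

This account rests on a few compounds, and the source may have more. Where it says the series, first, only, none or still open, it means among the compounds named here.

Compound 1 `CCOC(=O)c1sc(-c2cccc(NC(=O)c3ccc(C(F)(F)F)cc3)c2)nc1Nc1ccc(N2CCN(C)CC2)cc1` — in a functional assay on Ramos cells (Homo sapiens) for antiproliferative activity, read by CCK-8 assay, with a stated time of 72 h, tested at 40 uM (on this read-out lower numbers stand for less inhibition and higher numbers for more inhibition at the one concentration tested (going by the name of the read-out)), compound 1 gives 18.4%
Compound 2 `CCOC(=O)c1sc(-c2cccc(NC(=O)c3ccccc3)c2)nc1Nc1ccc(N2CCN(C)CC2)cc1` — compound 2 gives 77.1%
Compound 3 `CCOC(=O)c1sc(-c2cccc(NC(=O)c3ccc(C(F)(F)F)cn3)c2)nc1Nc1ccc(N2CCN(C)CC2)cc1` — compound 3 gives 19%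

Compound 2 stands highest of the three numbers; compound 3 sits far below it and compound 1 further still, both gaps beyond the scatter. The three share one core and differ only in the ring attached to the carbonyl of the amide. Compound 4 `CCOC(=O)c1sc(-c2cccc(NC(=O)c3ccco3)c2)nc1Nc1ccc(N2CCN(C)CC2)cc1` is the next member of this set, and it differs from compound 2 in one place: furan-2-yl in place of phenyl on a carbonyl carbon.

Among the compounds with values here, two measured steps bear on this. The step of a number 58.7 percentage points higher from compound 1 to compound 2 (beyond the scatter) shows that taking the trifluoromethyl off the amide aryl raised inhibition sharply, and the step of a number 58.1 percentage points lower from compound 2 to compound 3 (beyond the scatter) shows that exchanging the phenyl for a trifluoromethyl-bearing pyridyl lowered it just as sharply. Both steps leaving compound 2 involve a trifluoromethyl group, which compound 4 does not carry; the pair of compounds 1 and 3, which differ only in the ring atom, sit within the scatter of each other. Within the data shown here, no measured step shows a bare heteroaryl ring in this position, so the direction is uncertain, and a moderate loss is expected, giving the step of a number 22.1 percentage points lower from compound 2 to compound 4 (beyond the scatter).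

Compound 4 is therefore estimated at 55%, within a wide range from 20% to 85%.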

Compound 4, a percentage reported as inhibition, at one concentration (the size of the read-out at that concentration, not a potency): 50.2%
The estimate for compound 4 lay 4.8 percentage points above the measured number, and the stated range covers the measured number.
By their numbers in this assay, from the lowest: compounds 1 and 3 (each within the scatter of the next); then compound 4; then compound 2.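

In this assay the step of a number 26.9 percentage points lower from compound 2 to compound 4 (beyond the scatter) shows that inhibition at this position also falls with a ring that carries no trifluoromethyl, so that group is not needed for a loss here. The step of a number 31.2 percentage points higher from compound 3 to compound 4 (beyond the scatter) and the step of a number 31.8 percentage points higher from compound 1 to compound 4 (beyond the scatter) show that furan-2-yl on the carbonyl carbon still keeps far more inhibition than either trifluoromethyl-bearing ring, placing this ring between those two and phenyl. No measurement given here explains this order.

Furan-2-yl differs from phenyl in both ring size and its ring oxygen, and the compounds shown cannot separate these two changes. Also open, as far as these compounds go, is how thiophen-2-yl, with sulfur in the ring in place of oxygen, or a phenyl ring bearing an amine would read at this position.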